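Swapping Nitrooxy for Fluoro on the Sulfonyl Aryl Ring

This account rests on a few compounds, and the source may have more. Where it says the series, first, only, none or still open, it means among the compounds named here.

Compound 1 `O=C1/C(=C/c2ccccc2F)CN(S(=O)(=O)c2ccc(O[N+](=O)[O-])cc2)C/C1=C\c1ccccc1F` and compound 2 `O=C1/C(=C/c2ccc(F)cc2)CN(S(=O)(=O)c2ccc(O[N+](=O)[O-])cc2)C/C1=C\c1ccc(F)cc1` share one core and differ only in the placing of the fluorine on the two outer rings. In an ADME assay on L02 cells (Homo sapiens) for cytotoxicity, read by MTT assay, with a stated time of 24 h (on this read-out higher numbers stand for weaker inhibition and lower numbers for stronger inhibition), compound 1 gives 15500 nM, and compound 2 gives 16200 nM; the two numbers lie within the usual scatter of each other, so neither stands apart. Compound 3 `O=C1/C(=C/c2ccc(F)cc2)CN(S(=O)(=O)c2ccc(F)cc2)C/C1=C\c1ccc(F)cc1` is not yet measured. It differs from compound 2 in one place: fluoro in place of nitrooxy on an aromatic carbon. Within the data shown here, no measured pair shows what this change does in this assay, so the step is expected to stay within the scatter, at a 1.0-fold higher number from compound 2 to compound 3 (0.02 log units; within the scatter). Compound 3 is therefore estimated at 17000 nM in this assay, with a range from 6000 nM to 48000 nM.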

Compound 3, half-maximal inhibitory concentration: 14800 nM
Beside the measured number, compound 3's estimate is 1.1-fold (0.06 log units) above it, and the stated range covers the measured number.
By their numbers in this assay, from the lowest: compounds 3, 1 and 2 (each within the scatter of the next).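

Fluoro in place of nitrooxy on this aromatic carbon gives a 1.1-fold lower number from compound 2 to compound 3 (0.04 log units; within the scatter) in this assay and so adds a first reading for this position. The four heavy atoms of nitrooxy can give way to the single fluorine with no difference that stands clear of the scatter. Nothing measured on either group explains this result.

On these data alone, whether an amine or a carboxylic acid on this carbon would stay within the scatter remains open. So does whether fluoro in place of nitrooxy gives a similar step on the core of compound 1.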